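This account rests on a few compounds, and the source may have more. Where it says the series, first, only, none or still open, it means among the compounds named here.

Compound 1 `CCCCNC(=O)Nc1cc2nc(C3CCCCC3)[nH]c2cc1N(CC)CC` in an ADME assay on Vero cells (Chlorocebus sabaeus) for cytotoxicity, read by resazurin assay, with a stated time of 3 days (on this read-out lower numbers stand for stronger inhibition and higher numbers for weaker inhibition), gives > 100 ug/mL, which is a limit of the assay and not a number.
Compound 2 `CCOCCOC(=O)Nc1cc2nc(C3CCCCC3)[nH]c2cc1N(C)C` gives > 100 ug/mL, again a limit.
Compound 3 `CN(C)c1cc2[nH]c(C3CCCCC3)nc2cc1NC(=O)c1ccc(C(C)(C)C)cc1` gives > 100 ug/mL, also a limit.

Compound 1 therefore stands at the limit of this assay, and so do the other two compounds, since (the limit of > 100 ug/mL in this assay, at which 3 of the 3 values shown sit). Nothing in these three values sets compound 1 apart from compound 2 or compound 3.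

The compound not yet measured is compound 4 `CCN(CC)c1cc2[nH]c(C3CCCCC3)nc2cc1NC(=O)c1ccc(C)cc1`. It differs from compound 1 in one place: 4-methylphenyl in place of butylamino on a carbonyl carbon. For the measured compounds named here, the one measured step that touches the same position is the step from compound 2 to compound 3, a step that the two limits leave unreadable from compound 2 to compound 3, which also puts an aryl group on the carbonyl carbon but remains unreadable, as both its ends are limits. Going by the values given here, no measured step with a readable size bears on the change, so there is no ground on which to expect movement in this assay in either direction beyond the scatter, and the most probable outcome is that compound 4 again returns only a limit.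

Compound 4 is accordingly estimated at 120 ug/mL, with a range from 60 ug/mL to 250 ug/mL, which means an expected step that the limit leaves unreadable from compound 1 to compound 4.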

Compound 4, half-maximal inhibitory concentration: > 100 ug/mL
Compound 4 ended at the assay's limit; the forecaster's own chance of this, stated with the estimate: 80%; the middle value is on the limit's open side.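

No step can be read between compound 1 and compound 4 in this assay, since both values are limits and not numbers: the limit of > 100 ug/mL in this assay, at which 4 of the 4 values shown sit.

The compounds shown leave open where any of the four would fall in this assay, and so whether 4-methylphenyl in place of butylamino on a carbonyl carbon changes the read-out at all.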